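The compounds below may be only part of what the source reports. "The series", "measured", "known", "first", "only" and "open" are said of these compounds alone.

Measured in a physicochemical assay for solubility, in phosphate buffer, at pH 7.4; on this read-out higher numbers stand for higher solubility and lower numbers for lower solubility:
Compound 1 `CCOC(=O)c1c(-c2ccc(C(F)(F)F)cc2)[nH]c2cccc(OC)c2c1=O`: 22000 nM
Compound 2 `CCOC(=O)c1c(-c2ccc(OC)cc2)[nH]c2cccc(OC)c2c1=O`: > 100000 nM
Compound 3 `CCOC(=O)c1c(-c2ccc(C(C)(C)C)cc2)[nH]c2cccc(OC)c2c1=O`: 1000 nM

Compound 2 stands at the limit of > 100000 nM in this assay, at which 1 of the 3 values shown sits. Its reading is a limit and not a number.

Compound 4 `CCOC(=O)c1c(-c2cccc(F)c2)[nH]c2cccc(OC)c2c1=O` carries 3-fluorophenyl in place of 4-methoxyphenyl on an aromatic carbon.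

Among the measured compounds shown here, two measured steps concern the methoxy group of compound 2. One is an at least 4.5-fold higher number from compound 1 to compound 2 (0.65 log units; beyond the scatter), and the other is an at least 100-fold lower number from compound 2 to compound 3 (2.00 log units; beyond the scatter). Neither involves fluorine. Compound 2 holds the higher number in both, so a lower number is expected for compound 4 in this assay, with a size nearer to an at least 4.5-fold higher number from compound 1 to compound 2 (0.65 log units; beyond the scatter) than to an at least 100-fold lower number from compound 2 to compound 3 (2.00 log units; beyond the scatter). The estimated change is an at least 3.3-fold lower number from compound 2 to compound 4 (0.52 log units; beyond the scatter). Compound 4 is expected at 30000 nM, with an estimated range of 8000 nM to 90000 nM.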

Compound 4, solubility: > 100000 nM
Compound 4: no number, only a limit; the forecaster's own chance of this, stated with the estimate: 20%; middle value at least 3.3-fold (0.52 log units) from the limit.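

The readings of compound 2 and compound 4 in this assay are both limits and not numbers, and the step between them cannot be read: the limit of > 100000 nM in this assay, at which 2 of the 4 values shown sit.

The compounds shown leave open whether 3-fluorophenyl or 4-methoxyphenyl gives the higher number.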